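Swapping the sulfonyl aryl group in a receptor binding series

The compounds below may be only part of what the source reports. "The series", "measured", "known", "first", "only" and "open" are said of these compounds alone.

Measured so far:
compound 1 `COc1ccc2ncc(S(=O)(=O)c3ccc(C)cc3)c(N3CCC(C)CC3)c2c1` gives 90%
compound 2 `CC1CCN(c2c(S(=O)(=O)c3ccc(C#N)cc3)cnc3cc(Cl)ccc23)CC1` gives 70%
compound 3 `CCN(CC)c1c(S(=O)(=O)c2ccc(C)cc2)cnc2ccccc12` gives 78.3%

These three compounds were examined in an assay on isolated protein for displacement of a labelled ligand from metabotropic glutamate receptor 5 (Homo sapiens), with a stated time of 60 min, tested at 1 uM; on this read-out lower numbers stand for less inhibition and higher numbers for more inhibition at the one concentration tested (going by the name of the read-out). Compound 1 gives the highest of the three numbers; its nearest neighbour is compound 3, whose value lies beyond the scatter below it, and compound 2 lies further still below it. All three share a sulfonyl group joined to a six-membered aromatic ring of carbon only, and compound 1 and compound 3 both carry a 4-methylphenyl there.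

Compound 4 `COc1ccc2ncc(S(=O)(=O)c3ccc(OC)c(Cl)c3)c(N3CCC(C)CC3)c2c1` has not yet been measured in this assay. It differs from compound 1 in one place: 3-chloro-4-methoxyphenyl in place of 4-methylphenyl on a sulfonyl sulfur. For the measured compounds named here, no pair of measured compounds shows what such a swap on the sulfonyl sulfur does, so the direction of the step is open. The group that enters is larger and brings one hydrogen-bond acceptor; the expectation is a step of modest size, within or just beyond the scatter, with a slight lean downward. Compound 4 is therefore estimated at 80%, between 55% and 95%, an expected step of a number 10 percentage points lower from compound 1 to compound 4 (within the scatter).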

Compound 4, a percentage reported as inhibition, at one concentration (the size of the read-out at that concentration, not a potency): 21%
Estimate against measurement, compound 4: 59 percentage points above; measured number outside the range, below it.
By their numbers in this assay, from the lowest: compound 4; then compounds 2 and 3 (each within the scatter of the next); then compound 1.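

In this assay, the group on the sulfonyl sulfur turns out to matter a great deal: 3-chloro-4-methoxyphenyl in place of 4-methylphenyl gives a number 69 percentage points lower from compound 1 to compound 4 (beyond the scatter) while the rest of the molecule stays the same. For the compounds shown here, this is the first comparison here that changes only one place, and it shows that keeping a six-membered aromatic ring of carbon only on the sulfur does not by itself preserve inhibition at this position. Nothing available here accounts for the size of this step.

On these data alone, the swap adds a chlorine and a methoxy group and removes a methyl group all at once, so the contribution of each remains unknown. As far as these compounds go, how a plain phenyl group, or a ring carrying only a methoxy group or only a chlorine, would behave at this position stays open.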